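A few compounds are considered here, and "the series" means these few. Any claim that something is new, unique, unknown or untested is made for them only; others in the source may bear on it.

For the measured compounds named here, compound 3 `O=C(CCCCC[C@H](NC(=O)c1cc2c(Br)cccc2[nH]1)C(=O)NCc1ccccc1)NO` gives 1940 nM in a functional assay on NFF cells (Homo sapiens) for antiproliferative activity (on this read-out lower numbers stand for stronger inhibition and higher numbers for weaker inhibition), the second highest of the three numbers measured so far. Its nearest neighbour is compound 2 `O=C(CCCCC[C@H](NC(=O)OCc1ccccc1)C(=O)NCc1ccccc1)NO` at 1520 nM, and the step of a 1.3-fold higher number from compound 2 to compound 3 (0.11 log units; within the scatter) lies within the scatter. Compound 1 `O=C(/C=C/c1ccccc1)N[C@@H](CCCCCC(=O)NO)C(=O)NCc1ccccc1` gives 4010 nM, the step of a 2.1-fold lower number from compound 1 to compound 3 (0.32 log units; beyond the scatter) being beyond the scatter, as is a 2.6-fold lower number from compound 1 to compound 2 (0.42 log units; beyond the scatter).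

Compound 4 `O=C(CCCCC[C@H](NC(=O)c1cc2c(O)cccc2[nH]1)C(=O)NCc1ccccc1)NO` differs from compound 3 in one place: hydroxy in place of bromo on an aromatic carbon. Read one bond further out, 4-bromo-1H-indol-2-yl becomes 4-hydroxy-1H-indol-2-yl. Going by the values given here, none of the measured steps bears on this change directly: each of them exchanges the whole group on the carbonyl carbon, and no pair varies a single substituent on the indole ring. Among the compounds with values here, the two steps beyond the scatter are modest, and the one exchange between two aryl-type groups, compound 2 to compound 3, stays within the scatter. The expected step of a 1.0-fold higher number from compound 3 to compound 4 (0.01 log units; within the scatter) is therefore small and not beyond the scatter, in either direction. Compound 4 is estimated at 2000 nM in this assay, with a range of 800 nM to 5000 nM.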

Compound 4, half-maximal inhibitory concentration: 2210 nM
The estimate for compound 4 lay 1.1-fold (0.04 log units) below the measured number; the measured number falls inside the stated range.
By their numbers in this assay, from the lowest: compounds 2, 3, 4 and 1 (each within the scatter of the next, the first and the last beyond it).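

For the compounds shown here, on an aromatic carbon of the 1H-indol-2-yl group, hydroxy in place of bromo is the first change of a single substituent, and in this assay the step (a 1.1-fold higher number from compound 3 to compound 4 (0.06 log units; within the scatter)) stays within the scatter, even though the entering group adds a hydrogen-bond donor and a hydrogen-bond acceptor. The hydroxy compound also stays within the scatter of the benzyloxy compound (a 1.5-fold higher number from compound 2 to compound 4 (0.16 log units; within the scatter)) and, unlike the bromo compound (a 2.1-fold lower number from compound 1 to compound 3 (0.32 log units; beyond the scatter)), of the 2-phenylethenyl compound (a 1.8-fold lower number from compound 1 to compound 4 (0.26 log units; within the scatter)). Nothing available explains why this exchange leaves the number so little changed.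

On these data alone, whether an amine, a methoxy group or a carboxylic acid on this carbon would carry the number beyond the scatter remains open. So does whether bromo and hydroxy would behave alike on the other carbons of the same six-membered ring.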